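Moving from 2-bromophenyl to 4-chlorophenyl

The source may hold more compounds than are shown below. What is called first, only, known or untested is meant among the compounds shown, and "the series" means these compounds.

Measured in a toxicity assay on J774.A1 cells (Mus musculus) for cytotoxicity, read by SYBR Green assay, with a stated time of 1 h; a higher number here means that more compound is needed for the effect, a lower number that less compound is needed:
Compound 1 `CN(C)c1ccc2cc(-c3ccccc3F)c(N)nc2c1`: 1600 nM
Compound 2 `CN(C)c1ccc2cc(-c3ccccc3Br)c(N)nc2c1`: 12000 nM

Within the data shown here, of these two measured compounds, compound 2 stands highest at 12000 nM, and compound 1 is the only neighbour. The next compound, compound 3 `CN(C)c1ccc2cc(-c3ccc(Cl)cc3)c(N)nc2c1`, carries 4-chlorophenyl in place of 2-bromophenyl on an aromatic carbon. Among the measured compounds shown here, only one measured step bears on this change: a 7.5-fold higher number from compound 1 to compound 2 (0.88 log units; beyond the scatter). It is modest but beyond the scatter, and it swaps fluoro for bromo. For the measured compounds named here, no measured step shows what a 4-chlorophenyl group does, so the guidance is indirect. Compound 3 loses the bromo group that marks the higher of the two values, so a modest step toward a lower number is expected, no larger than the one measured, with compound 1 at 1600 nM as a rough guide to the lower side. The expected change is a 2.4-fold lower number from compound 2 to compound 3 (0.38 log units; beyond the scatter). For compound 3 the estimate is 5000 nM, with an expected range of 1500 nM to 16000 nM.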

Compound 3, half-maximal effective concentration: 2900 nM
Compound 3: the middle estimate sits 1.7-fold (0.24 log units) above what was measured, within the range that was stated.
By their numbers in this assay, from the lowest: compounds 1 and 3 (each within the scatter of the next); then compound 2.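

In this assay, 4-chlorophenyl in place of 2-bromophenyl on this aromatic carbon gives a 4.1-fold lower number from compound 2 to compound 3 (0.62 log units; beyond the scatter), so the high number of compound 2 does not carry over to this other halogen-bearing phenyl group. Setting 4-chlorophenyl in place of 2-fluorophenyl gives a 1.8-fold higher number from compound 1 to compound 3 (0.26 log units; within the scatter), so compound 1 and compound 3 cannot be told apart in this assay even though both the halogen and its place on the phenyl group differ, and among these three compounds only compound 2 stands apart. Nothing given here accounts for why the 2-bromophenyl group stands apart from the other two groups.

Every group shown at this position is a phenyl group carrying one halogen, and because the halogen and its place change together from compound 2 to compound 3, the two cannot be separated; a 2-chlorophenyl or 4-bromophenyl group would be needed to do so. Also open, on these data alone, is how this assay would read for a phenyl group carrying an amine or a carboxylic acid, or for a longer chain at this position.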